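Moving the Halogen: From Compound 2 to Compound 4

A few compounds are considered here, and "the series" means these few. Any claim that something is new, unique, unknown or untested is made for them only; others in the source may bear on it.

Compound 1 `Cc1cccc(Cn2cc(COc3ccc4c(=O)ccoc4c3)nn2)c1`: in a functional assay on HeLa cells (Homo sapiens) for cytotoxicity, read by MTT assay, with a stated time of 48 h (a higher number here means a weaker inhibitor, a lower number a stronger inhibitor), compound 1 gives > 100000 nM, a limit of the assay rather than a number.
Compound 2 `O=c1ccoc2cc(OCc3cn(Cc4ccc(Cl)cc4)nn3)ccc12`: compound 2 gives 37600 nM.
Compound 3 `O=c1ccoc2cc(OCc3cn(Cc4ccc(Br)cc4)nn3)ccc12`: compound 3 gives > 100000 nM, again a limit of the assay.

Among the measured compounds shown here, compound 2 therefore stands as the only measured number; the two other values sit at the limit of > 100000 nM in this assay, at which 2 of the 3 values shown sit. Compound 4 `O=c1ccoc2cc(OCc3cn(Cc4ccccc4F)nn3)ccc12` differs from compound 2 in one place: 2-fluorophenyl in place of 4-chlorophenyl on a saturated chain carbon bound to an aromatic nitrogen. For the measured compounds named here, two measured steps bear on this change. an at least 2.6-fold lower number from compound 1 to compound 2 (0.42 log units; beyond the scatter) and an at least 2.6-fold higher number from compound 2 to compound 3 (0.42 log units; beyond the scatter) both show that the group on the saturated chain carbon bound to the aromatic nitrogen moves the number by modest, readable amounts, and that compound 2 is flanked on both sides by limits. Going by the values given here, no measured step covers a fluoro group or a 2-substituted phenyl, so the direction is uncertain. A weakening step is expected for compound 4, a 2.1-fold higher number from compound 2 to compound 4 (0.33 log units; beyond the scatter), with the estimate 80000 nM (range 25000 nM to 250000 nM).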

Compound 4, half-maximal inhibitory concentration: > 100000 nM
Compound 4 was reported as a limit (the forecaster's own chance of this, stated with the estimate: 40%); middle value at least 1.2-fold (0.09 log units) away from the limit.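

Among the compounds shown here, compound 4 gives a limit of the assay, yet its step from the one measured compound still reads: an at least 2.6-fold higher number from compound 2 to compound 4 (0.42 log units; beyond the scatter). So a fluoro group on 2-fluorophenyl, in place of 4-chlorophenyl on this saturated chain carbon, does not keep the measurable value of compound 2. The steps to compound 4 from compound 1 and compound 3 cannot be read, and compound 2 stays alone among limits: the limit of > 100000 nM in this assay, at which 3 of the 4 values shown sit.

This change swaps the halogen and its ring position together, so the compounds shown cannot separate the two. Going by these compounds, a 2-chlorophenyl or 4-fluorophenyl group would do that, and a 4-aminophenyl group or a longer chain remains equally open.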